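Replacing 3,5-difluorophenyl with oxan-4-yl on a sulfonyl sulfur

The source may hold more compounds than are shown below. What is called first, only, known or untested is meant among the compounds shown, and "the series" means these compounds.

In a physicochemical assay for solubility, in phosphate buffer, with a stated time of 24 h, at pH 7.4, tested at 100 uM (on this read-out lower numbers stand for lower solubility and higher numbers for higher solubility), compound 1 `O=C(NCc1ccc(S(=O)(=O)c2ccccc2)cc1)N1Cc2ccncc2C1` gives 115000 nM and compound 2 `O=C(NCc1ccc(S(=O)(=O)c2ccccc2)cc1)N1Cc2cccnc2C1` gives 144000 nM. Compound 3 `O=C(NCc1ccc(S(=O)(=O)c2cc(F)cc(F)c2)cc1)N1Cc2ccncc2C1` gives 16000 nM, the lowest of the three numbers and beyond the scatter from both others. Compound 4 `O=C(NCc1ccc(S(=O)(=O)C2CCOCC2)cc1)N1Cc2ccncc2C1` has not yet been measured. It differs from compound 3 by oxan-4-yl in place of 3,5-difluorophenyl on a sulfonyl sulfur, with oxan-4-yl in place of 3,5-difluorophenyl on a sulfonyl sulfur.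

The most relevant evidence is a 7.2-fold lower number from compound 1 to compound 3 (0.86 log units; beyond the scatter), where 3,5-difluorophenyl replaced phenyl on that same sulfur. The other measured step, a 1.3-fold higher number from compound 1 to compound 2 (0.10 log units; within the scatter), leaves the group on the sulfur unchanged and says little here. Within the data shown here, no measured compound carries oxan-4-yl, so the expectation rests only on the loss of 3,5-difluorophenyl. The reference is compound 1 at 115000 nM, which differs from compound 3 only in that group. The expected change in this assay is a 6.9-fold higher number from compound 3 to compound 4 (0.84 log units; beyond the scatter), similar in size to the measured step but reversed in direction. For compound 4 the estimated value is 110000 nM, with an expected range from 45000 nM to 200000 nM.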

Compound 4, solubility: 206000 nM
Compound 4: the middle estimate sits 1.9-fold (0.27 log units) below what was measured; measured number above the stated range.
By their numbers in this assay, from the lowest: compound 3; then compounds 1, 2 and 4 (each within the scatter of the next).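

On the sulfonyl sulfur, a non-aromatic ring now stands in the place of the aromatic ones, and in this assay oxan-4-yl in place of 3,5-difluorophenyl gives a 13-fold higher number from compound 3 to compound 4 (1.11 log units; beyond the scatter). Set against phenyl, the same group gives a 1.8-fold higher number from compound 1 to compound 4 (0.25 log units; within the scatter), so among compounds 1, 3 and 4, which differ only on this sulfur, 3,5-difluorophenyl alone sets its compound apart. Nothing measured on these compounds bears on what lies behind this step.

The compounds shown leave open whether the ring oxygen of oxan-4-yl matters at all, which cyclohexyl, the carbon-only ring, would address. They also leave open whether a single fluorine on the phenyl ring, as in 3-fluorophenyl, would be enough to give a step of this kind.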